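This account rests on a few compounds, and the source may have more. Where it says the series, first, only, none or still open, it means among the compounds named here.

Compound 1 `CC1(COc2ncc(-c3ccc(F)nc3)cn2)CCn2cc([N+](=O)[O-])nc2O1`: > 64000 nM
Compound 2 `O=[N+]([O-])c1cn2c(n1)OC(COc1cccc(-c3ccc(F)cc3)n1)CC2`: 59000 nM

In an ADME assay on MRC5 cells (Homo sapiens) for cytotoxicity, read by resazurin assay, with a stated time of 72 h (a higher number here means a weaker inhibitor, a lower number a stronger inhibitor), compound 1 gives > 64000 nM. On these data alone, that entry is a limit of the assay and not a number, so the exact standing of compound 1 remains unknown: the limit of > 64000 nM in this assay, at which 1 of the 2 values shown sits. Compound 2, by contrast, has a measured number, 59000 nM.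

Compound 3 `O=[N+]([O-])c1cn2c(n1)OC(COc1ncc(-c3ccc(F)nc3)cn1)CC2` is compound 1 with one small edit: hydrogen in place of methyl on a saturated ring carbon. The rest of the structure stays the same. Going by the values given here, no measured pair of compounds isolates this change, so the forecast has little to lean on.

Compound 2 also carries hydrogen on that saturated ring carbon and gives 59000 nM, although it differs from compound 3 elsewhere. On that basis, no step beyond the usual scatter is expected in this assay, and compound 3 may also reach the limit of the assay. The expected change is an at least 1.0-fold lower number from compound 1 to compound 3 (0.02 log units; that floor lies within the scatter). For compound 3 the estimated value is 60000 nM, with an expected range from 25000 nM to 64000 nM.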

Compound 3, half-maximal inhibitory concentration: > 64000 nM
Compound 3: no number, only a limit; the forecaster's own chance of this, stated with the estimate: 60%; middle value at least 1.0-fold (0.02 log units) from the limit.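

In this assay compound 3 gives > 64000 nM, which is a limit of the assay and not a number. Compound 1 also stands at a limit, so no step can be read between compound 1 and compound 3: the limit of > 64000 nM in this assay, at which 2 of the 3 values shown sit. On these data alone, whether hydrogen in place of methyl on a saturated ring carbon changes the value at all, and by how much, stays open.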